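Aryl replacement on the quinolinone core: compound 3 to compound 4

The source may report more compounds than this note shows. Statements on the series, on what has been measured and on what is new or still open speak of the compounds shown alone.

Working notes on the series. Among the measured compounds shown here, in a functional assay on cells (Pituitary gland cell) for antagonist activity at Gonadotropin-releasing hormone receptor (Rattus norvegicus) (on this read-out lower numbers stand for stronger inhibition and higher numbers for weaker inhibition), compound 3 `Cc1cc(-c2c(O)nc3cc(Cl)c([N+](=O)[O-])cc3c2OCCC2CCCCN2)cc(C(C)O)c1` gives 63 nM, the second highest of the three numbers so far; compound 2 `O=C(Nc1cc2c(OCCC3CCCCN3)c(-c3ccc(Cl)c(Cl)c3)c(O)nc2cc1Cl)NC1CC1` gives 18 nM and compound 1 `COc1ccc(-c2c(O)nc3cc(Cl)c([N+](=O)[O-])cc3c2OCCC2CCCCN2)cc1OC` gives 600 nM. Compound 4 `O=[N+]([O-])c1cc2c(OCCC3CCCCN3)c(-c3cccc(Cl)c3)c(O)nc2cc1Cl` differs from compound 3 only at the aryl group: 3-chlorophenyl in place of 3-(1-hydroxyethyl)-5-methylphenyl on an aromatic carbon. For the measured compounds named here, the one measured step that bears on this position is the aryl exchange a 9.5-fold lower number from compound 1 to compound 3 (0.98 log units; beyond the scatter), which shows that the substituents on this ring can move this assay well beyond the scatter. Going by the values given here, compound 2 carries a 3,4-dichlorophenyl at the same place and sits lowest in this assay, but it also differs elsewhere, so no step to it is counted. The loss of the hydroxyethyl group, with its donor and acceptor, leaves the direction uncertain; a step of modest size, more likely toward a higher number, is expected a 1.6-fold higher number from compound 3 to compound 4 (0.20 log units; within the scatter). Compound 4 is therefore estimated at 100 nM in this assay, within 30 nM to 400 nM.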

Compound 4, half-maximal inhibitory concentration: 40 nM
For compound 4 the middle estimate is 2.5-fold (0.40 log units) above the measured one, within the range that was stated.
By their numbers in this assay, from the lowest: compound 2; then compounds 4 and 3 (each within the scatter of the next); then compound 1.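

In this assay the aryl exchange gives a 1.6-fold lower number from compound 3 to compound 4 (0.20 log units; within the scatter), so 3-(1-hydroxyethyl)-5-methylphenyl and 3-chlorophenyl cannot be told apart at this place, and the hydrogen-bond donor and acceptor of the hydroxyethyl group are not needed to hold the number seen for compound 3. The exchange from 3,4-dimethoxyphenyl gives a 15-fold lower number from compound 1 to compound 4 (1.18 log units; beyond the scatter), so two quite different aryl groups, one of them smaller and without donor or acceptor, both read well under compound 1. Nothing measured explains why these aryl groups read as they do.

Open, as far as these compounds go, is how an amine or a carboxylic acid in place of the chlorine of 3-chlorophenyl would read. Compound 2 differs from compound 4 in more than one place, so what its 3,4-dichlorophenyl contributes stays unresolved.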